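The source may hold more compounds than are shown below. What is called first, only, known or untested is meant among the compounds shown, and "the series" means these compounds.

Measured so far in an assay on K562 cells for displacement of a labelled ligand from Equilibrative nucleoside transporter 1 (Homo sapiens), read by flow cytometry, with a stated time of 45 min; on this read-out higher numbers stand for weaker inhibition and lower numbers for stronger inhibition:
compound 1, `CCCCNc1nc(SCc2ccc([N+](=O)[O-])cc2)c2ncn([C@@H]3O[C@H](CO)[C@@H](O)[C@H]3O)c2n1`, 325 nM
compound 2, `CCCCCNc1nc(SCc2ccc([N+](=O)[O-])cc2)c2ncn([C@@H]3O[C@H](CO)[C@@H](O)[C@H]3O)c2n1`, 357 nM
compound 3, `O=[N+]([O-])c1ccc(CSc2nc(NC3CCCCC3)nc3c2ncn3[C@@H]2O[C@H](CO)[C@@H](O)[C@H]2O)cc1`, 400 nM

Compound 1 gives the lowest of the three numbers, but its steps to both other compounds, a 1.1-fold higher number from compound 1 to compound 2 (0.04 log units; within the scatter) and a 1.2-fold higher number from compound 1 to compound 3 (0.09 log units; within the scatter), are within the scatter, as is a 1.1-fold higher number from compound 2 to compound 3 (0.05 log units; within the scatter). For the measured compounds named here, the three values do not separate, and no compound can be called the strongest. Across these three compounds the group on the nitrogen on the aromatic ring varies only among saturated alkyl groups, butyl, pentyl and cyclohexyl, and the read-out does not move.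

Compound 4, `CC(=O)Nc1nc(SCc2ccc([N+](=O)[O-])cc2)c2ncn([C@@H]3O[C@H](CO)[C@@H](O)[C@H]3O)c2n1`, is the next compound. Relative to compound 1 the change is acetyl in place of butyl on a nitrogen on an aromatic ring. Going by the values given here, none of the measured steps covers this kind of replacement: each of them swaps one alkyl group for another, whereas here a carbonyl-bearing group enters in place of the alkyl chain. Among the compounds with values here, the measured steps show only that the read-out tolerates changes in the size and shape of the alkyl group; they give no guide to an acetyl group. The expectation is therefore weakly held: a step to a higher number of modest size, with a wide range that also admits no change beyond the scatter. Compound 4 is expected to give 1000 nM in this assay, between 300 nM and 4000 nM, an expected step of a 3.1-fold higher number from compound 1 to compound 4 (0.49 log units; beyond the scatter).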

Compound 4, inhibition constant: 34 nM
The estimate for compound 4 lay 29-fold (1.47 log units) above the measured number, outside the stated range (below it).
By their numbers in this assay, from the lowest: compound 4; then compounds 1, 2 and 3 (each within the scatter of the next).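

In this assay, the group on the nitrogen on an aromatic ring, which gave no separable values among the saturated alkyl groups, proves able to move the read-out: acetyl in place of butyl gives a 9.6-fold lower number from compound 1 to compound 4 (0.98 log units; beyond the scatter), acetyl in place of pentyl gives an 11-fold lower number from compound 2 to compound 4 (1.02 log units; beyond the scatter), and acetyl in place of cyclohexyl gives a 12-fold lower number from compound 3 to compound 4 (1.07 log units; beyond the scatter). With all three steps beyond the scatter, compound 4 is the strongest of the four compounds shown, while compounds 1, 2 and 3 remain unseparated from one another. The change from butylamino to acetamido brings in a carbonyl and shortens the group at the same time, and nothing at hand explains the lower number.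

The compounds shown leave open whether the carbonyl or the smaller group goes with the step, a question that an ethyl group on the same nitrogen, set against acetyl, and a longer acyl group such as butanoyl, set against butyl, would address. Also open, as far as these compounds go, is how a plain amino group, a benzoyl group or a urea at this nitrogen would compare with acetyl.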